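Swapping the dimethylamino chain of compound 1

The compounds below may be only part of what the source reports. "The series", "measured", "known", "first", "only" and "open" are said of these compounds alone.

Within the data shown here, in a functional assay on cells (Neutrophil, Homo sapiens) for inhibition, read by transwell migration (on this read-out lower numbers stand for stronger inhibition and higher numbers for weaker inhibition), compound 1 (`COC(=O)c1c(NCCN(C)C)n(-c2ccccc2)c(=S)n(-c2ccccc2)c1=O`) gives 3.32 nM, the lower of the two numbers so far, and compound 2 (`CC(=O)c1c(NCCN(C)C)n(-c2ccccc2)c(=S)n(-c2ccccc2)c1=O`) gives 6.86 nM. Compound 3 (`COC(=O)c1c(NCC(OC)OC)n(-c2ccccc2)c(=S)n(-c2ccccc2)c1=O`) changes the chain instead: dimethoxymethyl in place of (dimethylamino)methyl on a saturated chain carbon bound to a nitrogen on an aromatic ring. Among the measured compounds shown here, the only measured step, a 2.1-fold higher number from compound 1 to compound 2 (0.32 log units; beyond the scatter), sits on a carbonyl carbon and bears on this change only loosely, as a guide to size. For the measured compounds named here, no measured step touches this chain, so direction is uncertain, and a rise to a weaker number is tentatively expected. The expected step is a 3.6-fold higher number from compound 1 to compound 3 (0.56 log units; beyond the scatter). Compound 3 is estimated at 12 nM, with an expected range of 2 nM to 70 nM.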

Compound 3, half-maximal inhibitory concentration: 31.2 nM
Compound 3: middle estimate off by 2.6-fold (0.41 log units), on the low side; low and high end bracket the measured number.
By their numbers in this assay, from the lowest: compound 1; then compound 2; then compound 3.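

In this assay, among these compounds, the chain is not a neutral site: 2,2-dimethoxyethyl in place of 2-(dimethylamino)ethyl gives a 9.4-fold higher number from compound 1 to compound 3 (0.97 log units; beyond the scatter), the first measured step at this position. The dimethylamino group is still not essential for activity, since compound 3 gives 31.2 nM without it. No supporting data bear on what lies behind this shift.

Still open, from the compounds shown here alone, is whether a cyclic amine such as morpholine or pyrrolidine would match compound 1 on this chain. Also open, going by these compounds, is how a longer chain carrying the dimethylamino group would read.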